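Removing a Hydroxy Group from a Glucagon Receptor Ligand

A few compounds are considered here, and "the series" means these few. Any claim that something is new, unique, unknown or untested is made for them only; others in the source may bear on it.

Of the compounds shown here, three sharing one core have been tested in an assay on CHO cells for inhibition of Glucagon receptor (Homo sapiens), tested at 20 uM; a lower number here means less inhibition, a higher number more inhibition at the concentration tested (going by the name of the read-out). Compound 1 `CCCCCc1c(C(C)C)nc(C(C)C)c(CO)c1-c1ccccc1CO` gives 44%, the highest of the three numbers. Compound 3 `CCC/C=C/c1c(C(C)C)nc(C(C)C)c(CO)c1-c1ccc(Cl)c(Cl)c1` gives 39% in this assay, a value that lies within the usual scatter of compound 1. Compound 2 `CCC/C=C/c1c(C(C)C)nc(C(C)C)c(CO)c1-c1ccc(S(C)(=O)=O)cc1` gives 14%, which lies beyond the scatter below compound 1. Compound 4 `CCCCCc1c(C(C)C)nc(C(C)C)c(CO)c1-c1ccccc1C` has not yet been measured. It differs from compound 1 in one place: hydrogen in place of hydroxy on a saturated chain carbon bound to an aromatic carbon. For the measured compounds named here, no step between measured compounds of this kind is available, so the size of this change cannot be read from the others. The step of a number 8 percentage points lower from compound 1 to compound 4 (within the scatter) is expected to be small, within the scatter. Compound 4 is estimated at 36% in this assay, with a range from 15% to 55%.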

Compound 4, a percentage reported as inhibition, at one concentration (the size of the read-out at that concentration, not a potency): 33%
Beside the measured number, compound 4's estimate is 3 percentage points above it; the measured number falls inside the stated range.
By their numbers in this assay, from the lowest: compound 2; then compounds 4, 3 and 1 (each within the scatter of the next, the first and the last beyond it).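

For the compounds shown here, this is the first step in the set that can be read at one place: in this assay, hydrogen in place of hydroxy on a saturated chain carbon bound to an aromatic carbon gives a number 11 percentage points lower from compound 1 to compound 4 (beyond the scatter). The hydroxy is thus not required for inhibition at the concentration tested, since compound 4 still gives 33%. Nothing shown accounts for the size of this step.

On these data alone, whether a methoxy group, an amine or a carboxylic acid at this place would give a higher or lower number remains open.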